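Swapping the Aryl Ether for an Isoxazole Ring

This account rests on a few compounds, and the source may have more. Where it says the series, first, only, none or still open, it means among the compounds named here.

Measured so far:
Compound 1 `CC(C)CCn1nc(-c2cccs2)c(O)c(C2=NS(=O)(=O)c3cc(OC(C)(C)C(N)=O)ccc3N2)c1=O`: 0.35 h
Compound 2 `CC(C)CCn1nc(-c2cccs2)c(O)c(C2=NS(=O)(=O)c3cc(OCC(=O)NO)ccc3N2)c1=O`: > 1 h

In an in vitro ADME assay on microsomes from liver (Homo sapiens) for metabolic stability, tested at 5 uM (a higher number here means that the compound lasts longer, a lower number that the compound disappears faster), compound 1 gives 0.35 h. For compound 2 the result is only a limit, > 1 h, so compound 2 stands at the limit of > 1 h in this assay, at which 1 of the 2 values shown sits, and no number is known for it. Going by the values given here, the one measured step, an at least 2.8-fold higher number from compound 1 to compound 2 (0.45 log units; beyond the scatter), concerns the group on the oxygen of the ring.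

Compound 3 `CC(C)CCn1nc(-c2cccs2)c(O)c(C2=NS(=O)(=O)c3cc(-c4cnoc4)ccc3N2)c1=O` changes that part of the molecule in a different way: 1,2-oxazol-4-yl in place of (hydroxycarbamoyl)methoxy on an aromatic carbon. Among the compounds with values here, no measured step covers this kind of change, and compound 2 itself is known only as a limit, so the direction for compound 3 is open. Compound 3 is therefore expected to land near compound 2, with the step of an at least 1.2-fold lower number from compound 2 to compound 3 (0.09 log units; that floor lies within the scatter) taken as the estimate, and its value is estimated at 0.8 h within 0.3 h to 2 h.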

Compound 3, half-life: 0.5 h
Beside the measured number, compound 3's estimate is 1.6-fold (0.20 log units) above it, within the range that was stated.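

In this assay, going by these compounds alone, the earlier compounds varied only the group on the ring oxygen, whereas the 1,2-oxazol-4-yl group shows that this aromatic carbon can also carry a five-membered aromatic ring with no oxygen link. Set against the 1-carbamoyl-1-methylethoxy group, this ring gives no distinguishable result, the step being a 1.4-fold higher number from compound 1 to compound 3 (0.15 log units; within the scatter). Against the (hydroxycarbamoyl)methoxy group the step is an at least 2.0-fold lower number from compound 2 to compound 3 (0.30 log units; that floor lies within the scatter), and its true size stays unknown because compound 2 is known only as a limit: the limit of > 1 h in this assay, at which 1 of the 3 values shown sits.

As far as these compounds go, it remains open which part of the (hydroxycarbamoyl)methoxy group goes with the limit of compound 2. Also open, from the compounds shown here alone, is how a carboxylic acid, an amine or a pyridine ring on this carbon would behave in this assay.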